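Aryl for neopentyl at the imidazole chain: compound 4

The source may report more compounds than this note shows. Statements on the series, on what has been measured and on what is new or still open speak of the compounds shown alone.

Measured compounds:
- compound 1 `O=C(O)c1ccccc1-c1ccc(CCc2ncc(CCC3CCCCC3)[nH]2)cc1`: 33 nM
- compound 2 `Cc1cccc(Cc2cnc(CCc3ccc(-c4ccccc4C(=O)O)cc3)[nH]2)c1`: 75 nM
- compound 3 `CC(C)(C)CCc1cnc(CCc2ccc(-c3ccccc3C(=O)O)cc2)[nH]1`: 6.2 nM

In an in vitro functional assay on cells for agonist activity at Bombesin receptor subtype-3 (Mus musculus), read by luminescence and calcium flux (on this read-out lower numbers stand for an effect already at smaller amounts and higher numbers for an effect only at larger amounts of compound), compound 3 gives the lowest number of the three, with compound 1 the nearest and compound 2 the furthest. The step of a 5.3-fold lower number from compound 1 to compound 3 (0.73 log units; beyond the scatter) and the step of a 12-fold lower number from compound 2 to compound 3 (1.08 log units; beyond the scatter) both run toward compound 3, so within this set a saturated, branched group on the saturated chain carbon bound to an aromatic carbon goes with the lower number, and an aromatic ring there with the higher one. Compound 4 `N#Cc1ccccc1Cc1cnc(CCc2ccc(-c3ccccc3C(=O)O)cc2)[nH]1` differs from compound 3 in exactly that place: 2-cyanophenyl in place of neopentyl on a saturated chain carbon bound to an aromatic carbon. The step most directly comparable is the reverse of a 12-fold lower number from compound 2 to compound 3 (1.08 log units; beyond the scatter), since 3-methylphenyl and 2-cyanophenyl are both six-membered aromatic rings of carbon on the same chain carbon. For the measured compounds named here, no measured pair shows what the nitrile itself does, so the estimate carries that uncertainty. Compound 4 is therefore expected to give a higher number, by a step near a 9.7-fold higher number from compound 3 to compound 4 (0.99 log units; beyond the scatter), in this assay. The estimate for compound 4 is 60 nM, within the range 15 nM to 250 nM.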

Compound 4, half-maximal effective concentration: 642 nM
For compound 4 the middle estimate is 11-fold (1.03 log units) below the measured one; measured number outside the range, above it.
By their numbers in this assay, from the lowest: compound 3; then compound 1; then compound 2; then compound 4.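

In this assay an aromatic ring on this chain carbon can cost far more than compound 2 suggested: 2-cyanophenyl in place of neopentyl gives a 100-fold higher number from compound 3 to compound 4 (2.02 log units; beyond the scatter) and 2-cyanophenyl in place of cyclohexylmethyl gives a 19-fold higher number from compound 1 to compound 4 (1.29 log units; beyond the scatter) in this set. The two aromatic rings are also not interchangeable, since 2-cyanophenyl in place of 3-methylphenyl gives an 8.6-fold higher number from compound 2 to compound 4 (0.93 log units; beyond the scatter) on the same chain carbon, so the ring's substituent matters as well as the ring itself. No evidence at hand accounts for the size of these steps. A 2-methylphenyl or a 3-cyanophenyl on this carbon would be needed to separate the nitrile from its place on the ring. Where a plain phenyl would fall among these compounds also remains open.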